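Changing the Aryl Group on the Ring Nitrogen

The compounds below may be only part of what the source reports. "The series", "measured", "known", "first", "only" and "open" are said of these compounds alone.

In an assay on isolated protein for inhibition of protein kinase C zeta type (Homo sapiens), with a stated time of 4 min, tested at 62.5 uM (on this read-out higher numbers stand for more inhibition at the one concentration tested (going by the name of the read-out) and lower numbers for less inhibition), compound 2 `CC(C)(C)C1=NN(c2ccc(Cl)cc2Cl)C(c2ccc(O)cc2)C1` gives 71%. Going by the values given here, that is the lower of the two numbers known so far: the only other measured compound, compound 1 `CC(C)(C)C1=NN(c2cccc(Cl)c2)C(c2ccc(O)cc2)C1`, gives 96.8% in this assay, and the two are separated by the step of a number 25.8 percentage points lower from compound 1 to compound 2 (beyond the scatter).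

Compound 3 `CC(C)(C)C1=NN(c2ccc(F)c(Cl)c2)C(c2ccc(O)cc2)C1` has not yet been measured. It differs from compound 2 in one place: 3-chloro-4-fluorophenyl in place of 2,4-dichlorophenyl on an amine nitrogen in a ring. Among the compounds with values here, the one measured step that bears on this change is a number 25.8 percentage points lower from compound 1 to compound 2 (beyond the scatter), a drop beyond the scatter when 3-chlorophenyl was replaced by 2,4-dichlorophenyl on the amine nitrogen in the ring. The 3-chloro-4-fluorophenyl group of compound 3 resembles the 3-chlorophenyl of compound 1 more closely than it resembles the 2,4-dichlorophenyl of compound 2, so part of that loss is expected to be recovered. Within the data shown here, the expected step is a number 17 percentage points higher from compound 2 to compound 3 (beyond the scatter) upward, although with only one informative step the range must stay wide. Compound 3 is therefore estimated at 88%, most likely between 70% and 99%.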

Compound 3, a percentage reported as inhibition, at one concentration (the size of the read-out at that concentration, not a potency): 98.8%
For compound 3 the middle estimate is 10.8 percentage points below the measured one; the range from low to high includes it.
By their numbers in this assay, from the lowest: compound 2; then compounds 1 and 3 (each within the scatter of the next).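

The step of a number 27.8 percentage points higher from compound 2 to compound 3 (beyond the scatter) in this assay shows that the lower reading of compound 2 does not extend to every aryl group with two halogens on the amine nitrogen in the ring, since the 3-chloro-4-fluorophenyl group of compound 3 also carries two. The step of a number 2 percentage points higher from compound 1 to compound 3 (within the scatter), with fluoro in place of hydrogen on an aromatic carbon, shows that this added halogen leaves a reading the scatter cannot separate from that of the 3-chlorophenyl group. Among these three compounds, only the 2,4-dichlorophenyl group stands apart, but nothing available here accounts for that difference.

The compounds shown leave open whether a plain phenyl, a 3-methoxyphenyl or a pyridyl group on this nitrogen would keep the reading, and which of the differences between the 2,4-dichlorophenyl and 3-chloro-4-fluorophenyl groups matters, as the step from compound 2 to compound 3 alters both halogens together. Since each reading comes from one concentration, they also leave open how compound 1 and compound 3 would compare in potency.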